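Swapping Methoxy for Trifluoromethyl on the Aromatic Ring

The compounds below may be only part of what the source reports. "The series", "measured", "known", "first", "only" and "open" are said of these compounds alone.

Measured so far in a functional assay on the whole organism (strain Swiss) with Mus musculus as the target, in the maximal electroshock model, with a stated time of 1 h, at a dose of 300 mg/kg by the intraperitoneal route; a higher number here means a stronger effect of the compound at the dose given, a lower number a weaker effect:
Compound 1 `CCC(C(=O)N1CCN(c2ccccc2)CC1)N1C(=O)CCC1=O` gives 75%.
Compound 2 `CCC(C(=O)N1CCN(c2cccc(OC)c2)CC1)N1C(=O)CCC1=O` gives 0%.

Going by the values given here, compound 2 stands at the lower of the two numbers; its only neighbour is compound 1, and the step between them, a number 75 percentage points lower from compound 1 to compound 2 (beyond the scatter), is large and beyond the scatter. That step shows that putting a methoxy on the aromatic carbon, where compound 1 carries hydrogen, removed the activity entirely.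

Compound 3 `CCC(C(=O)N1CCN(c2cccc(C(F)(F)F)c2)CC1)N1C(=O)CCC1=O` has not yet been measured. It differs from compound 2 in one place: trifluoromethyl in place of methoxy on an aromatic carbon. Among the compounds with values here, no measured step compares methoxy with trifluoromethyl directly, so the only guidance is a number 75 percentage points lower from compound 1 to compound 2 (beyond the scatter), which says that the bare ring is active and the methoxy-bearing ring is not. Whether trifluoromethyl will behave like hydrogen or like methoxy cannot be told from these two compounds alone, so the expectation for this assay is wide. Compound 3 is expected to give 30%, within a range from 0% to 75%, which means an expected step of a number 30 percentage points higher from compound 2 to compound 3 (beyond the scatter).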

Compound 3, a percentage reported as activity, at one dose (the size of the read-out at that dose, not a potency): 100%
Compound 3: the middle estimate sits 70 percentage points below what was measured, and the stated range ends below it.
By their numbers in this assay, from the lowest: compound 2; then compound 1; then compound 3.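

At this aromatic carbon, meta to a large group, this assay shows a number 100 percentage points higher from compound 2 to compound 3 (beyond the scatter) on replacing methoxy with trifluoromethyl, and a number 25 percentage points higher from compound 1 to compound 3 (beyond the scatter) on replacing hydrogen with trifluoromethyl. Carrying a group at this carbon therefore does not in itself abolish the effect: the outcome depends on which group sits there, with compound 3 holding the highest number of the three and methoxy the lowest, while the bare ring of compound 1 lies in between. Nothing measured here explains why these two groups give such different results.

On these data alone, with only hydrogen, methoxy and trifluoromethyl to compare, it remains open where a chlorine atom, a nitrile or an amine at this carbon would fall, and whether trifluoromethyl would give a similar result at another carbon of the ring. These numbers also come from a single dose, so they show the size of the effect at that dose and leave the potency of the compounds unknown.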